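Losing a Methoxy Group from Compound 3

The source may report more compounds than this note shows. Statements on the series, on what has been measured and on what is new or still open speak of the compounds shown alone.

Values in a functional assay on MCF7 cells (Homo sapiens) for antiproliferative activity, read by MTT assay, with a stated time of 48 h (on this read-out lower numbers stand for stronger inhibition and higher numbers for weaker inhibition), for the three measured compounds
Compound 1 `COc1ccc(-c2nc(C)c(C(=O)CSc3nc(N)c(C#N)c(-c4ccc(Cl)cc4)n3)s2)cc1` gives 11300 nM
Compound 2 `COc1ccc(-c2nc(C)c(C(=O)CSc3nc(N)c(C#N)c(-c4ccccc4)n3)s2)cc1` gives 72100 nM
Compound 3 `COc1ccc(-c2nc(C)c(C(=O)CSc3nc(-c4ccc(OC)c(OC)c4)c(C#N)c(=O)[nH]3)s2)cc1` gives 24000 nM

Among these three numbers, compound 3 stands second highest. Its value lies above that of compound 1 and below that of compound 2. Compound 4 `COc1ccc(-c2nc(SCC(=O)c3sc(-c4ccccc4)nc3C)[nH]c(=O)c2C#N)cc1OC` has not yet been measured in this assay. It differs from compound 3 by hydrogen in place of methoxy on an aromatic carbon, para to a large group, so that 4-methoxyphenyl becomes phenyl (hydrogen in place of methoxy on an aromatic carbon).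

Going by the values given here, only one measured step bears on this change, and only loosely. In a 6.4-fold higher number from compound 1 to compound 2 (0.80 log units; beyond the scatter), hydrogen takes the place of chloro on an aromatic carbon, and the step is modest but beyond the scatter. That step removes a different group, at a different place in the molecule, and the core of compound 1 differs from that of compound 3. It therefore suggests the direction of the change more firmly than its size. The expected change is smaller, an estimated 1.5-fold higher number from compound 3 to compound 4 (0.16 log units; within the scatter), and a result within the scatter would not be surprising. Compound 4 is expected to give about 35000 nM (estimated range 12000 nM to 90000 nM).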

Compound 4, half-maximal inhibitory concentration: 63700 nM
The estimate for compound 4 lay 1.8-fold (0.26 log units) below the measured number, within the range that was stated.
By their numbers in this assay, from the lowest: compound 1; then compound 3; then compounds 4 and 2 (each within the scatter of the next).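

In this assay, going by these compounds alone, the methoxy on the aromatic carbon para to a large group proves not to be a neutral substituent: its replacement by hydrogen, so that 4-methoxyphenyl becomes phenyl, brings a 2.7-fold higher number from compound 3 to compound 4 (0.42 log units; beyond the scatter) and thus gives a change beyond the scatter at a position that none of the earlier compounds varied. The step runs in the same direction as a 6.4-fold higher number from compound 1 to compound 2 (0.80 log units; beyond the scatter) and so adds a second case of a higher number on removal of a group, though the two steps concern different groups at different places on different cores and agree only in direction. Nothing shown here accounts for the loss of activity, so the step stands as an observation without an explanation.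

The compounds shown leave open whether a hydroxyl, an amine or a longer ether such as ethoxy at this position would keep the number near that of compound 3. They also leave open whether removing this methoxy would have a similar effect on the core of compound 1.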